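Swapping the Pyrazole Substituent in a Glucagon Receptor Ligand

This account rests on a few compounds, and the source may have more. Where it says the series, first, only, none or still open, it means among the compounds named here.

Compound 2 `CCCC(Oc1ccc(-n2cc(C(=O)N(C)C)cn2)cc1)c1ccc(C(=O)NCCC(=O)O)cc1` is the weakest of three compounds in an assay on cells for displacement of a labelled ligand from Glucagon receptor (Homo sapiens), in the presence of a further agent that is not named here; on this read-out lower numbers stand for stronger inhibition and higher numbers for weaker inhibition: it gives 6500 nM, while compound 1 `CCCC(Nc1ccc(-n2cc(C(F)(F)F)cn2)nc1)c1ccc(C(=O)NCCC(=O)O)cc1` gives 170 nM and compound 3 `O=C(O)CCNC(=O)c1ccc(C(Oc2ccc(-n3cc(C(F)(F)F)cn3)cc2)C2CCC2)cc1` gives 700 nM, each differing from compound 2 in more than one place. Compound 4 `CCCC(Oc1ccc(-n2cc3c(n2)CCCC3)cc1)c1ccc(C(=O)NCCC(=O)O)cc1` differs from compound 2 by one change: a group of 9 heavy atoms (7 carbon, 2 nitrogen; one five-membered aromatic ring with 2 hetero atoms, one six-membered non-aromatic ring of carbon only) in place of a group of 10 heavy atoms (6 carbon, 3 nitrogen, 1 oxygen; one five-membered aromatic ring with 2 hetero atoms), on an aromatic carbon. Among the compounds with values here, no measured pair isolates this change, so its effect is not known directly. Compound 4 is expected to show a lower number than compound 2, a step of a 7.2-fold lower number from compound 2 to compound 4 (0.86 log units; beyond the scatter) that is beyond the scatter but leaves it weaker than compound 1. The estimated value for compound 4 in this assay is 900 nM, within a range from 250 nM to 3500 nM.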

Compound 4, inhibition constant: 690 nM
The estimate for compound 4 lay 1.3-fold (0.12 log units) above the measured number; the range from low to high includes it.
By their numbers in this assay, from the lowest: compound 1; then compounds 4 and 3 (each within the scatter of the next); then compound 2.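

Exchanging the 4-(dimethylcarbamoyl)-1H-pyrazol-1-yl group, on an aromatic carbon para to a large group, for a group that keeps the five-membered aromatic ring and adds a six-membered non-aromatic ring of carbon only gives, in this assay, a 9.4-fold lower number from compound 2 to compound 4 (0.97 log units; beyond the scatter). Within the data shown here, this is the first direct reading at this position, and it shows that the dimethylcarbamoyl group is not needed to keep the compound's strength in this test. Nothing available explains the step.

Going by these compounds, whether the gain comes from losing the dimethylcarbamoyl group or from adding the carbon ring stays open. A pyrazole carrying only a methyl group at this position could help separate the two.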